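The source may hold more compounds than are shown below. What is called first, only, known or untested is meant among the compounds shown, and "the series" means these compounds.

Compounds measured so far:
- Compound 1, `C=CCc1cc2c(cc1O)C(C)(C)C(CCc1ccc(OC)cc1)O2`: 52 nM
- Compound 2, `CC1(C)c2cc(O)c(CCCOc3ccccc3)cc2OC1CCc1ccccc1`: 40 nM
- Compound 3, `Oc1cc2c(cc1CCCOc1ccccc1)OC(CCc1ccccc1)C2`: 23 nM

All three were tested in an assay for inhibition of Polyunsaturated fatty acid 5-lipoxygenase (Rattus norvegicus); on this read-out higher numbers stand for weaker inhibition and lower numbers for stronger inhibition. Compound 3 gives the smallest number of the three, yet compound 2 lies within the usual scatter of it, so these two cannot be told apart on this read-out. Compound 1 is different: its number stands beyond the scatter above that of compound 3, so compound 3 inhibits more strongly than compound 1. Among the measured compounds shown here, no pair of the measured compounds differs in only one place, so none of these gaps can be tied to a single structural change.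

The next compound, compound 4, `Oc1cc2c(cc1CCCSc1ccncc1)OC(CCc1ccccc1)C2`, keeps the shared core and the chain of compound 3 and alters only the end of that chain: (pyridin-4-yl)sulfanyl in place of phenoxy on a saturated chain carbon, three bonds along the chain from an aromatic carbon. For the measured compounds named here, nothing among the measured compounds shows how this assay responds to such a swap. With no guide from the data, the expected step from compound 3 to compound 4 in this assay is small, a 1.7-fold higher number from compound 3 to compound 4 (0.24 log units; within the scatter), and may not reach beyond the scatter in either direction. On that basis compound 4 is estimated at 40 nM, with a range from 12 nM to 130 nM.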

Compound 4, half-maximal inhibitory concentration: 8 nM
Beside the measured number, compound 4's estimate is 5.0-fold (0.70 log units) above it; measured number outside the range, below it.
By their numbers in this assay, from the lowest: compound 4; then compounds 3, 2 and 1 (each within the scatter of the next, the first and the last beyond it).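

Among the compounds shown here, changing the end of the chain is the first change here that can be read on its own, and in this assay it gives a 2.9-fold lower number from compound 3 to compound 4 (0.46 log units; beyond the scatter) as a modest step that lies beyond the usual scatter. At this place, on a saturated chain carbon, three bonds along the chain from an aromatic carbon, phenoxy is therefore not required: (pyridin-4-yl)sulfanyl, also of 7 heavy atoms, takes its place and the number falls. The swap alters two things at once, with sulfur replacing the oxygen link and a ring nitrogen entering the aromatic ring, and no measurement shown explains the gain or assigns it to either alteration.

Still open, from the compounds shown here alone, is which alteration matters: phenylsulfanyl would keep the sulfur without the ring nitrogen, while (pyridin-4-yl)oxy would keep the ring nitrogen without the sulfur. Also unanswered is whether the lower number would survive with the ring nitrogen moved, as in (pyridin-3-yl)sulfanyl, or with a longer chain carrying the same end group.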